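Aryl swap on compound 2: notes toward compound 3

A few compounds are considered here, and "the series" means these few. Any claim that something is new, unique, unknown or untested is made for them only; others in the source may bear on it.

Measured so far in an in vitro assay on HEK385-7 cells for displacement of a labelled ligand from prostaglandin D2 receptor 2 (Homo sapiens); a lower number here means a stronger inhibitor, a higher number a weaker inhibitor:
compound 1, `Nc1nc(-c2ccc(Cl)cc2)c(CC(=O)O)s1`, gives > 100000 nM, which is a limit of the assay and not a number.
compound 2, `O=C(O)Cc1sc(C(c2ccc(F)cc2)c2ccc(F)cc2)nc1-c1ccoc1`, gives 14 nM.

For the measured compounds named here, compound 2 therefore holds the only number seen in this assay; the one other result is a limit, compound 1 sitting at the limit of > 100000 nM in this assay, at which 1 of the 2 values shown sits. Going by the values given here, no single-change step joins compound 1 to compound 2, so the pair shows only that one value is a limit and the other a number.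

Compound 3, `N#Cc1ccc(-c2nc(C(c3ccc(F)cc3)c3ccc(F)cc3)sc2CC(=O)O)cc1`, is not yet measured. It differs from compound 2 in one place: 4-cyanophenyl in place of furan-3-yl on an aromatic carbon. The carboxymethyl group and the large group are kept. Among the compounds with values here, with no measured single-change step to lean on, the expectation is a step of no size beyond the usual scatter, namely a 1.1-fold higher number from compound 2 to compound 3 (0.03 log units; within the scatter). For compound 3 the estimate in this assay is 15 nM, within 4 nM to 60 nM.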

Compound 3, half-maximal inhibitory concentration: 150 nM
Beside the measured number, compound 3's estimate is 10-fold (1.00 log units) below it, and the stated range ends below it.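

For the compounds shown here, the first single-change step falls at this position. With the carboxymethyl group and the large group kept, 4-cyanophenyl in place of furan-3-yl gives an 11-fold higher number from compound 2 to compound 3 (1.03 log units; beyond the scatter) in this assay and so shows that the aromatic group on this carbon affects the result. Compound 3 at 150 nM is still a measured number and not a limit of the assay, so this position accepts a six-membered aromatic ring of carbon only without a complete loss of the read-out. Nothing shown accounts for the size of this step.

Going by these compounds alone, the single step does not separate the exchange of ring from the presence of the nitrile. From the compounds shown here alone, whether a plain phenyl or a thiophen-3-yl on this carbon would read closer to compound 2 or to compound 3 remains open.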